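From Methoxymethyl to Isopropoxymethyl

The source may hold more compounds than are shown below. What is called first, only, known or untested is meant among the compounds shown, and "the series" means these compounds.

In a functional assay on MES-SA cells (Homo sapiens) for inhibition, with a stated time of 72 h (on this read-out higher numbers stand for weaker inhibition and lower numbers for stronger inhibition), compound 1 (`COCc1cc(CN2CCCCC2)c(O)c2ncccc12`) gives 9330 nM and compound 2 (`COCc1cc(CN2CCC(C)CC2)c(O)c2ncccc12`) gives 6170 nM on the same shared core. These two values lie within the scatter of each other, so compound 2 stands level with compound 1 and neither can be ranked ahead. Compound 3 (`CC1CCN(Cc2cc(COC(C)C)c3cccnc3c2O)CC1`) differs from compound 2 by having isopropyl in place of methyl on an oxygen on a saturated carbon. Going by the values given here, the only measured step (a 1.5-fold lower number from compound 1 to compound 2 (0.18 log units; within the scatter)) lies within the scatter and concerns methyl in place of hydrogen on a saturated ring carbon, not this oxygen. It is therefore a loose guide, and no step beyond the scatter is expected in this assay for this change. The expected step is small (a 1.2-fold lower number from compound 2 to compound 3 (0.09 log units; within the scatter)) and its direction is uncertain. For compound 3 the estimated value is 5000 nM (expected range 1800 nM to 14000 nM).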

Compound 3, half-maximal inhibitory concentration: 2820 nM
Compound 3: middle estimate off by 1.8-fold (0.25 log units), on the high side, within the range that was stated.
By their numbers in this assay, from the lowest: compound 3; then compounds 2 and 1 (each within the scatter of the next).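

In this assay, replacing methyl with isopropyl on this oxygen gives a 2.2-fold lower number from compound 2 to compound 3 (0.34 log units; beyond the scatter), a modest change but one that goes beyond the usual scatter. Going by these compounds alone, the only earlier step, a 1.5-fold lower number from compound 1 to compound 2 (0.18 log units; within the scatter), stayed within the scatter and concerned a saturated ring carbon, so this is the first sign that the group on this oxygen can shift the number. No measurement here explains why the larger group gives stronger inhibition, and one pair of compounds offers no explanation of its own.

As far as these compounds go, it remains open whether a longer chain such as n-butyl, or a chain ending in an amine or a carboxylic acid, would lower the number further or raise it again. Also open, from the compounds shown here alone, is whether isopropyl would give a similar step on the core of compound 1 .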